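Hydroxy to hydrogen across two cores

A few compounds are considered here, and "the series" means these few. Any claim that something is new, unique, unknown or untested is made for them only; others in the source may bear on it.

In a functional assay on HeLa cells (Homo sapiens) for cytotoxicity, read by XTT assay, with a stated time of 72 h (on this read-out lower numbers stand for stronger inhibition and higher numbers for weaker inhibition), compound 1 `COc1ccc(Cc2ccc3ccccc3c2)c(OC)c1OC` gives 200 nM. Compound 2 `COc1ccc(C(O)c2ccc3ccccc3c2)c(OC)c1OC` reaches only a limit of this assay, > 10000 nM. The change from compound 2 to compound 1 is hydrogen in place of hydroxy on a saturated chain carbon bound to two aromatic carbons and gives an at least 50-fold lower number from compound 2 to compound 1 (1.69 log units; beyond the scatter); how far that step really goes is bounded by the limit of > 10000 nM in this assay, at which 1 of the 3 values shown sits. Compound 3 `COc1ccc(C(O)c2ccc3c(ccn3C)c2)c(OC)c1OC` carries the hydroxy on a different core and in this assay gives 2500 nM; the difference between the two cores is not broken down here. Compound 4 `COc1ccc(Cc2ccc3c(ccn3C)c2)c(OC)c1OC` is the matching compound without the hydroxy, and the change is hydrogen in place of hydroxy on a saturated chain carbon bound to two aromatic carbons, the same kind of change as from compound 2 to compound 1. The step is expected to be a 42-fold lower number from compound 3 to compound 4 (1.62 log units; beyond the scatter), resting on an at least 50-fold lower number from compound 2 to compound 1 (1.69 log units; beyond the scatter). Compound 4 is estimated at 60 nM, with a range from 10 nM to 400 nM.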

Compound 4, half-maximal inhibitory concentration: 240 nM
For compound 4 the middle estimate is 4.0-fold (0.60 log units) below the measured one; the measured number falls inside the stated range.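

In this assay, hydrogen in place of hydroxy lowers the number on both cores, and the step on the second core is a 10-fold lower number from compound 3 to compound 4 (1.02 log units; beyond the scatter). The direction carries over from one core to the other, but the size does not carry over as a fixed amount: the same change on two cores in this assay, an at least 50-fold lower number (1.69 log units; beyond the scatter) from compound 2 to compound 1 and a 10-fold lower number (1.02 log units; beyond the scatter) from compound 3 to compound 4, at least 4.8-fold (0.68 log units) apart, beyond the scatter of two such steps. Compound 2 is only a limit, > 10000 nM, so the gap between the steps has a lower bound and no known true size: the limit of > 10000 nM in this assay, at which 1 of the 4 values shown sits.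

As far as these compounds go, it remains open whether an amine, a fluorine or a methoxy on the saturated chain carbon bound to two aromatic carbons would give numbers closer to those with hydrogen or those with hydroxy. Two cores also cannot show how large the step would be on a third core.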